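Moving the phenyl substituent on a triazole-linked bicyclic lactam

This account rests on a few compounds, and the source may have more. Where it says the series, first, only, none or still open, it means among the compounds named here.

Measured so far in a functional assay on HepG2 cells (Homo sapiens) for inhibition, read by MTT assay, with a stated time of 24 h; a higher number here means a weaker inhibitor, a lower number a stronger inhibitor:
- compound 1, `COc1ccccc1-n1cc(CN2C(=O)C[C@@H]3CC[C@@]2(C)C3(C)C)nn1`: 110 nM
- compound 2, `CC1(C)[C@H]2CC[C@]1(C)N(Cc1cn(-c3cccc(O)c3)nn1)C(=O)C2`: 70 nM
- compound 3, `CC1(C)[C@H]2CC[C@]1(C)N(Cc1cn(-c3cccc(Br)c3)nn1)C(=O)C2`: 20 nM

Compound 1 shows the highest number of the three. The step of a 1.6-fold lower number from compound 1 to compound 2 (0.20 log units; within the scatter) stays within the scatter, whereas a 5.5-fold lower number from compound 1 to compound 3 (0.74 log units; beyond the scatter) is a modest, real gain, and a 3.5-fold lower number from compound 2 to compound 3 (0.54 log units; beyond the scatter) separates the two 3-substituted analogues.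

Compound 4, `Cc1cccc(-n2cc(CN3C(=O)C[C@@H]4CC[C@@]3(C)C4(C)C)nn2)c1`, differs from compound 1 in one place: 3-methylphenyl in place of 2-methoxyphenyl on an aromatic nitrogen. Both prior steps away from the 2-methoxyphenyl of compound 1 lowered the number, one within the scatter, one beyond it. A similar outcome is expected here, with a 2.8-fold lower number from compound 1 to compound 4 (0.44 log units; beyond the scatter) as the estimated step. Compound 4 is therefore expected to give 40 nM in this assay, with a range of 15 nM to 120 nM.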

Compound 4, half-maximal inhibitory concentration: 300 nM
Compound 4: the middle estimate sits 7.5-fold (0.88 log units) below what was measured; measured number outside the range, above it.
By their numbers in this assay, from the lowest: compound 3; then compounds 2 and 1 (each within the scatter of the next); then compound 4.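

The step of a 2.7-fold higher number from compound 1 to compound 4 (0.44 log units; beyond the scatter) shows that leaving the 2-methoxyphenyl does not always lower the number, so this position can move either way. Among the 3-substituted phenyl groups the substituent itself counts: methyl gives a 15-fold higher number from compound 3 to compound 4 (1.18 log units; beyond the scatter) against bromo and a 4.3-fold higher number from compound 2 to compound 4 (0.63 log units; beyond the scatter) against hydroxy. No measurement at hand accounts for these differences.

From the compounds shown here alone, whether bromo keeps its advantage elsewhere on the phenyl ring stays open. So does the effect of an amine or a carboxylic acid in place of methyl.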